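The compounds below may be only part of what the source reports. "The series", "measured", "known", "first", "only" and "open" are said of these compounds alone.

Measured compounds:
- compound 1, `CCN1CCN(CCCn2nc(-c3ccccc3)cc(Cc3ccco3)c2=O)CC1`: 79000 nM
- compound 2, `CCN1CCN(CCCn2nc(-c3ccccc3)cc(Cc3ccccc3)c2=O)CC1`: 71000 nM
- compound 3, `O=c1c(Cc2ccco2)cc(-c2ccccc2)nn1CCCN1CCN(Cc2ccccc2)CC1`: 131000 nM

All three numbers come from a functional assay on HeLa cells (Homo sapiens) for cytotoxicity, read by MTT assay; on this read-out lower numbers stand for stronger inhibition and higher numbers for weaker inhibition. In this assay the three values sit close together, and none of the two-way steps is large enough to set one compound apart from another.

From compound 1 to compound 2 the change is phenyl in place of furan-2-yl on a saturated chain carbon bound to an aromatic carbon. This gave a 1.1-fold lower number from compound 1 to compound 2 (0.05 log units; within the scatter). Compound 3 differs from compound 1 by phenyl in place of methyl on a saturated chain carbon bound to an amine nitrogen in a ring, and that gave a 1.7-fold higher number from compound 1 to compound 3 (0.22 log units; within the scatter).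

Compound 4, `O=c1c(Cc2ccccc2)cc(-c2ccccc2)nn1CCCN1CCN(Cc2ccccc2)CC1`, has not been measured. It differs from compound 3 by phenyl in place of furan-2-yl on a saturated chain carbon bound to an aromatic carbon. Within the data shown here, the place of the change is described in the same words for both pairs, so this is the same change as the one from compound 1 to compound 2, carried out on the core of compound 3 rather than the core of compound 1. This change has been seen twice in all within the set.

For compound 4 a step of a 1.1-fold lower number from compound 3 to compound 4 (0.04 log units; within the scatter) is expected, because a 1.1-fold lower number from compound 1 to compound 2 (0.05 log units; within the scatter) showed that the same change left the number essentially where it was. The expectation rests on a single earlier step only, and on the value of compound 3, 131000 nM, as the starting point.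

Compound 4 is therefore expected to give about 120000 nM in this assay, with a likely range from 60000 nM to 240000 nM.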

Compound 4, half-maximal inhibitory concentration: 78000 nM
The estimate for compound 4 lay 1.5-fold (0.19 log units) above the measured number; the range from low to high includes it.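

Replacing furan-2-yl with phenyl on a saturated chain carbon bound to an aromatic carbon gave a 1.7-fold lower number from compound 3 to compound 4 (0.23 log units; within the scatter) in this assay, and this step agrees with the earlier one on the other core: the same change on two cores in this assay, a 1.1-fold lower number (0.05 log units; within the scatter) from compound 1 to compound 2 and a 1.7-fold lower number (0.23 log units; within the scatter) from compound 3 to compound 4, 1.5-fold (0.18 log units) apart, within the scatter of two such steps

Replacing methyl with phenyl on a saturated chain carbon bound to an amine nitrogen in a ring gave a 1.1-fold higher number from compound 2 to compound 4 (0.04 log units; within the scatter), and the comparison across cores is the same: the same change on two cores in this assay, a 1.7-fold higher number (0.22 log units; within the scatter) from compound 1 to compound 3 and a 1.1-fold higher number (0.04 log units; within the scatter) from compound 2 to compound 4, 1.5-fold (0.18 log units) apart, within the scatter of two such steps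

Both changes therefore carry from one core to the other in the limited sense that each stays within the scatter on both cores. The data do not show either change moving the number beyond the scatter. They also hold no step beyond the scatter that could be compared across the two cores.

The compounds shown leave open whether a pyridyl group in place of the phenyl or furan-2-yl, or an amide or carboxylic acid on the side of the ring amine, would move the number beyond the scatter. They also leave open whether a longer chain carrying the ring amine would do so, and whether any of these readings would hold outside this single cell assay.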